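The source may report more compounds than this note shows. Statements on the series, on what has been measured and on what is new or still open speak of the compounds shown alone.

Measured compounds:
compound 1, `N#C/C(=C\c1ccc(O)c(O)c1)C(=O)OCC1OC1c1ccccc1`, gives 49.7%;
compound 2, `CCOC(=O)/C(C#N)=C/c1ccc(O)c(O)c1`, gives 21.8%;
compound 3, `C/C(=C\c1ccc(O)c(O)c1)C(=O)OC/C=C/c1ccccc1`, gives only the limit < 0%.

These three were tested in a functional assay on the whole organism (strain CD-1) for inhibition, with Mus musculus as the target, in the writhing test, with stated times of 15 min and 20 min, at a dose of 10 mg/kg by the subcutaneous route; a lower number here means less inhibition, a higher number more inhibition at the dose given (going by the name of the read-out). For compound 3 the reading is a limit of the assay rather than a number, as the record the limit of < 0% in this assay, at which 1 of the 3 values shown sits, shows, so where compound 3 stands is known only as far as that limit reaches. Compound 4, `NC/C(=C\c1ccc(O)c(O)c1)C(=O)OC/C=C/c1ccccc1`, has not yet been tested. It differs from compound 3 in a single place: amino in place of hydrogen on a saturated chain carbon bound to a double-bonded chain carbon. Cut one bond further out, the same change reads methyl to aminomethyl. Within the data shown here, no measured pair differs in only this way, so the size of the step can be judged from compound 3 alone. With compound 3 sitting at the limit, a move upward out of that limit seems the more likely outcome, though a step no larger than the usual scatter is also plausible. The step of a number at least 10 percentage points higher from compound 3 to compound 4 (that floor lies within the scatter) is therefore expected to be a small rise in this assay. Compound 4 is estimated at 10%, between -10% and 35%.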

Compound 4, a percentage reported as inhibition, in the whole organism at one dose (the size of the read-out at that dose, not a potency): 36.4%
The estimate for compound 4 lay 26.4 percentage points below the measured number, outside the stated range (above it).
By their numbers in this assay, from the lowest: compound 2; then compound 4; then compound 1. At a limit, below all of these: compound 3.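

In this assay, putting amino in place of hydrogen on a saturated chain carbon bound to a double-bonded chain carbon gives a number at least 36.4 percentage points higher from compound 3 to compound 4 (beyond the scatter). The earlier compounds shown here included no pair differing in one place, so they could say nothing about this position; this pair shows that the change from methyl to aminomethyl here is enough to carry the reading clear of the scatter. The true size of the step remains unknown, as compound 3 has only a limit and not a number: the limit of < 0% in this assay, at which 1 of the 4 values shown sits.

The compounds shown leave open whether the gain needs the amino group itself, since neither a hydroxyl nor a dimethylamino group stands at this place. They also leave open how a longer chain, such as aminoethyl, would read.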